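Replacing phenyl with difluorobenzyl on the saturated ring

This account rests on a few compounds, and the source may have more. Where it says the series, first, only, none or still open, it means among the compounds named here.

Measured so far:
Compound 1 `CC(C(=O)NCc1ccc(C(F)(F)F)nc1N(C)c1ccccc1)c1ccc(NS(C)(=O)=O)c(F)c1` gives 57.4 nM in a functional assay on CHO-K1 cells for antagonist activity at transient receptor potential cation channel subfamily V member 1 (Homo sapiens), read by FLIPR; on this read-out lower numbers stand for stronger inhibition and higher numbers for weaker inhibition.
Compound 2 `CC(C(=O)NCc1ccc(C(F)(F)F)nc1N1CCC(c2ccccc2)CC1)c1ccc(NS(C)(=O)=O)c(F)c1` gives 25 nM in this assay.

Going by the values given here, compound 2 stands at the lower of the two numbers, and the single measured step, a 2.3-fold lower number from compound 1 to compound 2 (0.36 log units; beyond the scatter), lies beyond the scatter. Compound 3 `CC(C(=O)NCc1ccc(C(F)(F)F)nc1N1CCC(Cc2ccc(F)c(F)c2)CC1)c1ccc(NS(C)(=O)=O)c(F)c1` differs from compound 2 in one place: 3,4-difluorobenzyl in place of phenyl on a saturated ring carbon. Among the compounds with values here, no measured step touches this saturated ring carbon; the step from compound 1 to compound 2 concerns the group on the aromatic carbon and says nothing about this change. Compound 3 is therefore expected to show no step beyond the scatter, no change at the digits printed from compound 2 to compound 3 (within the scatter). The estimate for compound 3 is 25 nM, within 8 nM to 80 nM.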

Compound 3, half-maximal inhibitory concentration: 30 nM
For compound 3 the middle estimate is 1.2-fold (0.08 log units) below the measured one; the range from low to high includes it.
By their numbers in this assay, from the lowest: compounds 2, 3 and 1 (each within the scatter of the next, the first and the last beyond it).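

At this saturated ring carbon, three ring bonds from the ring nitrogen, 3,4-difluorobenzyl can stand in place of phenyl with a 1.2-fold higher number from compound 2 to compound 3 (0.08 log units; within the scatter) in this assay. The position therefore takes a group of nine heavy atoms in place of one of six without a change beyond the scatter. No measurement given here accounts for this result.

Compound 2 and compound 3 alone cannot separate the contribution of the added carbon from that of the two fluorines. On these data alone, it remains open how an unsubstituted benzyl, an amine or a carboxylic acid at this carbon would read.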